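The source may hold more compounds than are shown below. What is called first, only, known or untested is meant among the compounds shown, and "the series" means these compounds.

Two compounds built on a shared core have been examined in a functional assay for activation of Alpha-1D adrenergic receptor (Homo sapiens); on this read-out lower numbers stand for an effect already at smaller amounts and higher numbers for an effect only at larger amounts of compound. Compound 1 `Cc1noc(-c2ccccc2NCC2=NCCN2)n1` carries a 3-methyl-1,2,4-oxadiazol-5-yl group; in this assay compound 1 gives < 5020 nM, which is a limit of the assay and not a number. Compound 2 `FC(F)(F)c1cccnc1-c1ccccc1NCC1=NCCN1` has also been tested; in this assay compound 2 gives < 100000 nM, again a limit rather than a number. For the measured compounds named here, compound 1 therefore stands only at a limit, and the one other value shown is a limit as well, so no step between measured compounds can be stated, and the limits the limit of < 5020 nM in this assay, at which 1 of the 2 values shown sits, and the limit of < 100000 nM in this assay, at which 1 of the 2 values shown sits, are all that the measurements say.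

Compound 3 `CO/N=C/c1ccccc1NCC1=NCCN1` has not been measured. It differs from compound 1 by a group of 4 heavy atoms (2 carbon, 1 nitrogen, 1 oxygen; no ring) in place of a group of 6 heavy atoms (3 carbon, 2 nitrogen, 1 oxygen; one five-membered aromatic ring with 3 hetero atoms), on an aromatic carbon: the five-membered aromatic ring with 3 hetero atoms leaves, and a group of 4 heavy atoms with no ring and 1 double bond outside aromatic rings enters on the aromatic carbon.

Going by the values given here, with no measured step to lean on, the change from compound 1 to compound 3 is expected to move this assay by a small amount, possibly not beyond the scatter, in no fixed direction; that expected step is a step that the limit leaves unreadable from compound 1 to compound 3. Compound 3 is estimated to give 2500 nM in this assay, within a range from 250 nM to 25000 nM.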

Compound 3, half-maximal effective concentration: < 5020 nM
Compound 3: only a limit was reported; the forecaster's own chance of this, stated with the estimate: 40%; the middle value does not contradict the limit.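

In this assay no step can be read from compound 1 to compound 3, because both compounds are reported only as a limit of the assay and not as a number: the limit of < 5020 nM in this assay, at which 2 of the 3 values shown sit. The compounds shown leave open whether the 3-methyl-1,2,4-oxadiazol-5-yl group and the open-chain group that replaces it in compound 3 differ in effect at all.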